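This account rests on a few compounds, and the source may have more. Where it says the series, first, only, none or still open, it means among the compounds named here.

Measured compounds:

Compound 1, `CCOC(=O)c1sc(-c2cccc(NC(=O)c3ccc(F)cc3)c2)nc1Nc1ccc(N2CCN(C)CC2)cc1`: in a functional assay on Ramos cells (Homo sapiens) for antiproliferative activity, read by CCK-8 assay, with a stated time of 72 h (a lower number here means a stronger inhibitor, a higher number a weaker inhibitor), compound 1 has no reported result, its entry reading "not determined" (no result reported).

Compound 2, `CN1CCN(c2ccc(Nc3nc(-c4cccc(NC(=O)c5ccc(C(F)(F)F)cc5)c4)sc3C(N)=O)cc2)CC1`: in this assay compound 2 gives 1580 nM.

Compound 2 therefore stands alone on the numbers: its value in this assay is the only one known here, and compound 1, which carries an ethyl ester where compound 2 carries a primary amide, contributes no number to compare against. Among the measured compounds shown here, no measured pair differing in a single place is available, so nothing about the size of any step has been observed directly.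

Compound 3, `CN1CCN(c2ccc(Nc3nc(-c4cccc(NC(=O)c5ccc(F)cc5)c4)sc3C(N)=O)cc2)CC1`, is the next compound to be measured. It differs from compound 2 in one spot: fluoro in place of trifluoromethyl on an aromatic carbon. The benzamide ring thus loses its trifluoromethyl group and gains a single fluorine atom in the same position.

For the measured compounds named here, with no observed step to lean on, the expected step is a 1.6-fold higher number from compound 2 to compound 3 (0.20 log units; within the scatter), a modest weakening that may well sit inside the usual scatter of repeated measurements. For compound 3 the estimated result in this assay is 2500 nM, with a plausible range from 800 nM to 8000 nM.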

Compound 3, half-maximal inhibitory concentration: 1420 nM
Compound 3: the middle estimate sits 1.8-fold (0.25 log units) above what was measured, within the range that was stated.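

In this assay, the trifluoromethyl group on the aromatic carbon para to a large group gives way to fluoro with a 1.1-fold lower number from compound 2 to compound 3 (0.05 log units; within the scatter), so the two compounds cannot be told apart. Among the compounds shown here, this is the first direct look at this position, and it shows that the 4-(trifluoromethyl)phenyl and 4-fluorophenyl versions read the same in this cell test, even though 4 heavy atoms leave and only 1 heavy atom enters. No measurement shown here accounts for this result, so it remains an observation without an explanation.

From the compounds shown here alone, a single swap between two groups that each carry fluorine says little about the position as a whole, and it remains open whether an amine, a carboxylic acid, a methoxy group or a longer alkyl chain in the same place would leave the number just as unmoved. Going by these compounds, the step from the primary amide of compound 3 to the ethyl ester of compound 1 cannot be read, as compound 1 has no result, so what that part of the molecule contributes also stays unknown.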